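Replacing the ethylphenyl amide with a pyridyl amide

This account rests on a few compounds, and the source may have more. Where it says the series, first, only, none or still open, it means among the compounds named here.

Measured compounds:
compound 1 `O=C(CN1CCN(c2ccccn2)CC1)Nc1cccnc1`: 25800 nM
compound 2 `CCc1cccc(NC(=O)CN2CCN(c3ccc(Cl)cn3)CC2)c1`: 10400 nM

Of the compounds shown here, two have been tested in an assay on cells for antagonist activity at D(4) dopamine receptor (Homo sapiens), read by luminescence and beta-arrestin recruitment, with a stated time of 90 min; a higher number here means a weaker inhibitor, a lower number a stronger inhibitor. Compound 1 gives 25800 nM and compound 2 gives 10400 nM; of the two numbers, compound 2 holds the lower one, and the gap between them lies beyond the usual scatter. The structures differ in two places, so no single structural change can be tied to that gap.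

Compound 3 `O=C(CN1CCN(c2ccc(Cl)cn2)CC1)Nc1cccnc1` has not yet been measured. It differs from compound 2 in one place only: pyridin-3-yl in place of 3-ethylphenyl on an amide-type nitrogen. Compound 3 therefore carries the same pyridin-3-yl on the amide-type nitrogen as compound 1, while keeping the chloro-substituted ring of compound 2. Within the data shown here, with no step between measured compounds available in which only this change occurs, the expectation has to rest on the weak showing of compound 1 with 25800 nM. Compound 3 is expected to lose activity relative to compound 2, a step of a 2.1-fold higher number from compound 2 to compound 3 (0.33 log units; beyond the scatter) in this assay. The estimate for compound 3 is 22000 nM, with a range from 8000 nM to 60000 nM.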

Compound 3, half-maximal inhibitory concentration: 23500 nM
For compound 3 the middle estimate is 1.1-fold (0.03 log units) below the measured one; measured number inside the range.
By their numbers in this assay, from the lowest: compound 2; then compounds 3 and 1 (each within the scatter of the next).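

In this assay, the exchange of 3-ethylphenyl for pyridin-3-yl on the amide-type nitrogen, which the earlier pair could not separate from the chloro change, now stands alone: it gives a 2.3-fold higher number from compound 2 to compound 3 (0.35 log units; beyond the scatter) as a modest loss that lies beyond the scatter. Chloro in place of hydrogen on an aromatic carbon gives a 1.1-fold lower number from compound 1 to compound 3 (0.04 log units; within the scatter) and so has no readable effect while pyridin-3-yl sits on the amide-type nitrogen. Among these compounds, of the two changes separating compound 1 from compound 2, only the one on the amide-type nitrogen therefore has a step beyond the scatter, although this rests on a single pair.

The compounds shown leave open whether chloro would also make no readable difference with 3-ethylphenyl on the amide-type nitrogen, and whether the ethyl group or the carbon-only ring accounts for the step, a question that a plain phenyl or a 3-methylphenyl group would bear on. Nothing measured here gives a reason for either step.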